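Same Swap Carried onto a Dimethylamino Benzamide Core

The source may hold more compounds than are shown below. What is called first, only, known or untested is meant among the compounds shown, and "the series" means these compounds.

The measured compounds:
compound 1, `Cc1ccc(NC(=O)CCN(Cc2ccc(C(=O)NO)cc2)C(=O)c2cc(C)cc(C)c2)cc1`, with 380 nM;
compound 2, `Cc1cc(C)cc(C(=O)N(CCC(=O)NCc2ccccc2)Cc2ccc(C(=O)NO)cc2)c1`, with 2030 nM;
compound 3, `CN(C)c1ccc(C(=O)N(CCC(=O)NCc2ccccc2)Cc2ccc(C(=O)NO)cc2)cc1`, with 1160 nM.

All three share a hydroxamic acid arm and were tested in a functional assay on CHP-134 cells (Homo sapiens) for antiproliferative activity, with a stated time of 72 h; a lower number here means a stronger inhibitor, a higher number a weaker inhibitor. Compound 4, `Cc1ccc(NC(=O)CCN(Cc2ccc(C(=O)NO)cc2)C(=O)c2ccc(N(C)C)cc2)cc1`, has not yet been measured there.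

Compound 2 and compound 1 differ in one place: 4-methylphenyl in place of benzyl on an amide-type nitrogen. That change gave a 5.3-fold lower number from compound 2 to compound 1 (0.73 log units; beyond the scatter), so compound 1 has the lowest number of the three measured compounds, and its steps to the others lie beyond the scatter.

Compound 3 is related to compound 2 by a different change, on the other end of the molecule: 4-(dimethylamino)phenyl in place of 3,5-dimethylphenyl on a carbonyl carbon. That step was a 1.8-fold lower number from compound 2 to compound 3 (0.24 log units; within the scatter), so these two cannot be told apart with confidence.

Compound 4 is built from compound 3 by 4-methylphenyl in place of benzyl on an amide-type nitrogen. The place of this change is described in the same words as for the step from compound 2 to compound 1, so it is the same change made on a slightly different core. If it behaves as it did there, compound 4 is expected to show a step of about a 5.3-fold lower number from compound 3 to compound 4 (0.72 log units; beyond the scatter), resting on the single earlier example a 5.3-fold lower number from compound 2 to compound 1 (0.73 log units; beyond the scatter) and on compound 3 at 1160 nM as the starting point. On that basis, compound 4 is estimated at 220 nM, with a range from 90 nM to 550 nM.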

Compound 4, half-maximal inhibitory concentration: 540 nM
Compound 4: middle estimate off by 2.5-fold (0.39 log units), on the low side; the range from low to high includes it.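

In this assay, putting 4-methylphenyl in place of benzyl on the amide-type nitrogen gave a 2.1-fold lower number from compound 3 to compound 4 (0.33 log units; beyond the scatter) and so pointed the same way on both cores, and the two step sizes cannot be told apart: the same change on two cores in this assay, a 5.3-fold lower number (0.73 log units; beyond the scatter) from compound 2 to compound 1 and a 2.1-fold lower number (0.33 log units; beyond the scatter) from compound 3 to compound 4, 2.5-fold (0.40 log units) apart, within the scatter of two such steps

The other change, 4-(dimethylamino)phenyl in place of 3,5-dimethylphenyl on a carbonyl carbon, gave a 1.4-fold higher number from compound 1 to compound 4 (0.15 log units; within the scatter) and stays within the scatter on both cores, so neither pair can be separated with confidence: the same change on two cores in this assay, a 1.8-fold lower number (0.24 log units; within the scatter) from compound 2 to compound 3 and a 1.4-fold higher number (0.15 log units; within the scatter) from compound 1 to compound 4, 2.5-fold (0.40 log units) apart, within the scatter of two such steps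

Going by these compounds alone, this is still only two cores, so it does not show that the swap would work on a third, and it does not fix one size for the step, since the two steps agree only within the scatter of the measurements.

The compounds shown leave open whether the methyl of the 4-methylphenyl group matters or whether a plain phenyl or a 4-chlorophenyl on that nitrogen would do as well, and a longer chain such as 2-phenylethyl would extend the comparison with benzyl. They also leave open how a carboxylic acid or a morpholine in place of the dimethylamino group would behave on the carbonyl side of the molecule.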